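The compounds below may be only part of what the source reports. "The series", "measured", "known", "first", "only" and "open" are said of these compounds alone.

Measured compounds in a functional assay on ACHN cells (Homo sapiens) for antiproliferative activity, read by MTT assay, with a stated time of 96 h; a lower number here means a stronger inhibitor, a higher number a weaker inhibitor:
- compound 1, `O=C1C2=C(C(=O)c3ncccc31)C1(CS2)NC(=O)N(c2ccccc2)C1=O`, 21 nM
- compound 2, `Cc1ccc(N2NC(=O)NC3(CSC4=C3C(=O)c3ncccc3C4=O)C2=O)cc1`, 500 nM
- compound 3, `O=C1NN(c2ccc(Cl)cc2)C(=O)C2(CSC3=C2C(=O)c2ncccc2C3=O)N1`, 360 nM

Compound 1 holds the lowest number of the three; compound 3 stands nearest and compound 2 furthest, both well beyond the scatter. Going by the values given here, compound 2 and compound 3 share a core that differs from that of compound 1, so their values show only that the group on the phenyl ring moved little: a 1.4-fold lower number from compound 2 to compound 3 (0.14 log units; within the scatter).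

Compound 4, `CC(C)(C)c1ccc(N2C(=O)NC3(CSC4=C3C(=O)c3ncccc3C4=O)C2=O)cc1`, is not yet measured. It differs from compound 1 by tert-butyl in place of hydrogen on an aromatic carbon. Among the compounds with values here, no measured step places a tert-butyl group on this ring, and the only measured step on the phenyl ring, from methyl to chloro in the other core, stays within the scatter. Taken together this gives no sign of a large shift in this assay, though a group of this size on the aromatic carbon carries more uncertainty than a small one. Compound 4 is therefore expected to land close to compound 1, with a mild drift towards higher numbers allowed: a 1.7-fold higher number from compound 1 to compound 4 (0.22 log units; within the scatter). The estimate for compound 4 is 35 nM, in the range 10 nM to 130 nM.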

Compound 4, half-maximal inhibitory concentration: 150 nM
Compound 4: the middle estimate sits 4.3-fold (0.63 log units) below what was measured; measured number above the stated range.
By their numbers in this assay, from the lowest: compound 1; then compound 4; then compounds 3 and 2 (each within the scatter of the next).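

Working notes on the phenyl ring: in this assay, phenyl to 4-(tert-butyl)phenyl on the core of compound 1 gives a 7.1-fold higher number from compound 1 to compound 4 (0.85 log units; beyond the scatter) and is the first change on this ring to pass beyond the scatter. The earlier step on the ring, a 1.4-fold lower number from compound 2 to compound 3 (0.14 log units; within the scatter), was chloro in place of methyl in another core, so it gave no sign that this position responds to a substituent. No measurement at hand speaks to the reason for the new step.

With only hydrogen and tert-butyl shown at this position on the core of compound 1, it remains open whether methyl, chloro, methoxy or a carboxylic acid would stay near the parent value. As far as these compounds go, it is also open whether tert-butyl would give a similar step in the core shared by compound 2 and compound 3.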